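Thiazolyl in place of methoxyphenyl on the piperazine nitrogen

A few compounds are considered here, and "the series" means these few. Any claim that something is new, unique, unknown or untested is made for them only; others in the source may bear on it.

Of the compounds shown here, two have been measured in a functional assay on HEK293 cells with D(4) dopamine receptor (Homo sapiens) as the target, read by FLIPR; on this read-out higher numbers stand for larger maximal responses and lower numbers for smaller maximal responses. Compound 1 `O/N=C(\CCN1CCN(c2ncccn2)CC1)c1ccccc1` gives 49% in this assay. Compound 2 `CCO/N=C(\CCN1CCN(c2ccccc2OC)CC1)c1ccccc1` gives 76% in this assay and thus stands highest of the two, with compound 1 a clear distance below it, beyond the usual scatter. Compound 3 `CCO/N=C(\CCN1CCN(c2nccs2)CC1)c1ccccc1` has not yet been measured. It differs from compound 2 in one place: 1,3-thiazol-2-yl in place of 2-methoxyphenyl on an amine nitrogen in a ring. Because compound 1 gives 49%, a lower response than compound 2 seems possible for compound 3, although compound 1 differs from compound 3 in more than one place, so the comparison is loose. A moderate downward step is expected from compound 2 to compound 3, a number 16 percentage points lower from compound 2 to compound 3 (beyond the scatter), though one within reach of the scatter cannot be excluded. In this assay compound 3 is estimated at 60%, expected to lie between 40% and 82%.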

Compound 3, largest response reached (reported as efficacy), in percent of the reference or control that the assay uses: 72%
Compound 3: middle estimate off by 12 percentage points, on the low side; low and high end bracket the measured number.
By their numbers in this assay, from the lowest: compound 1; then compounds 3 and 2 (each within the scatter of the next).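

Among these compounds, the exchange of 2-methoxyphenyl for 1,3-thiazol-2-yl on an amine nitrogen in a ring, read in this assay, gives a number 4 percentage points lower from compound 2 to compound 3 (within the scatter) and is the first change at this position that can be read on its own. The maximal response at this nitrogen therefore does not depend on keeping the six-membered aromatic ring of carbon only: a five-membered aromatic ring with 2 hetero atoms, with 5 heavy atoms in place of 8, serves within the scatter in this pair. Nothing at hand explains why the two groups give such close responses.

Going by these compounds, whether other groups on this nitrogen, such as pyridin-2-yl or a plain phenyl, also hold the response remains open. So does the effect of a propyl chain in place of the ethyl group on the oxime oxygen, and compound 1 differs from compound 3 in too many places to settle either question.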